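Methyl in place of hydrogen on the fused ring nitrogen

The source may report more compounds than this note shows. Statements on the series, on what has been measured and on what is new or still open speak of the compounds shown alone.

The series shares an amide-linked core carrying a bicyclic ether unit; compound 1 `COc1ccc(-n2c(=O)c(C(=O)Nc3ccc(Oc4ccnc5[nH]ccc45)cc3)cc3cccnc32)cc1`, compound 2 `O=C(Nc1ccc(Oc2ccnc3[nH]ccc23)cc1)c1cc2cccnc2n(-c2ccc(Br)cc2F)c1=O` and compound 3 `O=C(Nc1ccc(Oc2ccnc3[nH]ccc23)cc1)c1cc2cccnc2n(-c2ccc(C(F)(F)F)cc2Cl)c1=O` differ in the aryl group on the ring nitrogen of that core. In a functional assay on U-87MG ATCC cells for antiproliferative activity against U-87 MG (Homo sapiens), read by MTT assay, with a stated time of 72 h (a higher number here means a weaker inhibitor, a lower number a stronger inhibitor), compound 1 gives 2350 nM, and compound 3 gives 6030 nM, the highest of the two numbers reported, with a 2.6-fold higher number from compound 1 to compound 3 (0.41 log units; beyond the scatter). For compound 2 the assay gives "not determined" (no result reported).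

Compound 4 `Cn1ccc2c(Oc3ccc(NC(=O)c4cc5cccnc5n(-c5ccc(C(F)(F)F)cc5Cl)c4=O)cc3)ccnc21` differs from compound 3 by methyl in place of hydrogen on an aromatic nitrogen. Within the data shown here, no measured step changes this position, so the only step available, that from compound 1 to compound 3, concerns a different part of the molecule and does not bear directly on it. With nothing to indicate a gain, compound 4 is expected to sit close to or somewhat weaker than compound 3, with a step of a 1.5-fold higher number from compound 3 to compound 4 (0.17 log units; within the scatter) in this assay. Compound 4 is therefore estimated at 9000 nM, within a range from 3000 nM to 30000 nM.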

Compound 4, half-maximal inhibitory concentration: 12600 nM
The estimate for compound 4 lay 1.4-fold (0.15 log units) below the measured number, and the stated range covers the measured number.
By their numbers in this assay, from the lowest: compound 1; then compound 3; then compound 4.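

In this assay, among these compounds, the change of hydrogen to methyl on the aromatic nitrogen of the five-membered ring gives a 2.1-fold higher number from compound 3 to compound 4 (0.32 log units; beyond the scatter) and so provides the first measured reading at this position. The number moves in the direction of a weaker inhibitor, which shows that this position is not indifferent to substitution in this assay, although the step is modest and rests on a single pair of compounds. Nothing given here explains the step.

The compounds shown leave open whether ethyl or a longer chain ending in an amine on that nitrogen would raise the number further. They also leave open whether methyl at this position would give a step of similar size alongside the 4-methoxyphenyl group of compound 1.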